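Two fluoronitrophenyl variants of a glutamate-bearing diaminopyrimidinol

The compounds below may be only part of what the source reports. "The series", "measured", "known", "first", "only" and "open" are said of these compounds alone.

Compound 1 `Nc1nc(N)c(CCCN(Cc2ccc(NC(CCC(=O)O)C(=O)O)cc2)c2ccc([N+](=O)[O-])c(F)c2F)c(O)n1` and compound 2 `Nc1nc(N)c(CCCN(Cc2ccc(NC(CCC(=O)O)C(=O)O)cc2)c2cc(F)ccc2[N+](=O)[O-])c(O)n1` share a core that carries free acids, while compound 3 `CC(C)(C)OC(=O)CCC(Nc1ccc(CN(CCCc2c(N)nc(N)nc2O)c2cc(F)ccc2[N+](=O)[O-])cc1)C(=O)OC(C)(C)C` carries the corresponding tert-butyl esters; the difference between the two cores is not broken down here. In a functional assay on CCRF-CEM cells (Homo sapiens) for cytotoxicity, in the absence of a further agent (a higher number here means a weaker inhibitor, a lower number a stronger inhibitor), compound 1 gives only a limit, > 100000 nM. Compound 2 likewise gives only a limit in this assay, > 100000 nM. Compound 3 gives 12000 nM in this assay. The change from compound 2 to compound 1, (2,3-difluoro-4-nitrophenyl in place of 5-fluoro-2-nitrophenyl on an amine nitrogen), makes a step that the two limits leave unreadable from compound 2 to compound 1, unreadable due to the limit of > 100000 nM in this assay, at which 2 of the 3 values shown sit. Compound 4 `CC(C)(C)OC(=O)CCC(Nc1ccc(CN(CCCc2c(N)nc(N)nc2O)c2ccc([N+](=O)[O-])c(F)c2F)cc1)C(=O)OC(C)(C)C` carries the same change on the core of compound 3, (2,3-difluoro-4-nitrophenyl in place of 5-fluoro-2-nitrophenyl on an amine nitrogen). Since the measured step is unreadable, the expectation for compound 4 rests on compound 3 alone, and a step of a 1.7-fold higher number from compound 3 to compound 4 (0.22 log units; within the scatter) is estimated. Compound 4 is therefore expected to give about 20000 nM in this assay, within 5000 nM to 80000 nM.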

Compound 4, half-maximal inhibitory concentration: 20000 nM
Estimate against measurement, compound 4: no gap at the digits printed; the range from low to high includes it.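

In this assay, placing 2,3-difluoro-4-nitrophenyl in place of 5-fluoro-2-nitrophenyl on the core bearing tert-butyl esters makes a 1.7-fold higher number from compound 3 to compound 4 (0.22 log units; within the scatter), so the two compounds cannot be told apart here. On the free-acid core, the step from compound 2 to compound 1 cannot be read, as both values are limits and not numbers: the limit of > 100000 nM in this assay, at which 2 of the 4 values shown sit.

Only one core therefore gives a readable step, and the series shown does not establish whether the change behaves alike on both cores. The compounds shown leave open how ethyl esters would read in place of the tert-butyl esters. They also leave open the effect of a nitrile in place of the nitro group on the ring.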